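The compounds below may be only part of what the source reports. "The series", "measured", "known", "first", "only" and "open" are said of these compounds alone.

Measured compounds in a functional assay on MCF cells (Homo sapiens) for antiproliferative activity, with a stated time of 72 h; on this read-out lower numbers stand for stronger inhibition and higher numbers for weaker inhibition:
Compound 1 `OC[C@H]1O[C@@H](n2cnc3c(NCc4ccc(F)cc4)ncnc32)[C@H](O)[C@@H]1O` gives 21000 nM.
Compound 2 `OC[C@H]1O[C@@H](n2cnc3c(NCc4ccccc4Br)ncnc32)[C@H](O)[C@@H]1O` returns only the limit > 166000 nM.
Compound 3 `OC[C@H]1O[C@@H](n2cnc3c(NCc4ccc(F)c(F)c4F)ncnc32)[C@H](O)[C@@H]1O` returns only the limit > 166000 nM.

For the measured compounds named here, compound 1 holds the only real number; the other two values are limits, as the limit of > 166000 nM in this assay, at which 2 of the 3 values shown sit, records. The steps of an at least 7.9-fold higher number from compound 1 to compound 2 (0.89 log units; beyond the scatter) and an at least 7.9-fold higher number from compound 1 to compound 3 (0.89 log units; beyond the scatter) both show that exchanging the 4-fluorophenyl of compound 1 for another aryl group weakens inhibition in this assay. The step that the two limits leave unreadable from compound 2 to compound 3 cannot be read from the two limits.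

Compound 4 `Cc1cccc(CNc2ncnc3c2ncn3[C@@H]2O[C@H](CO)[C@@H](O)[C@H]2O)c1O` carries 2-hydroxy-3-methylphenyl in place of 4-fluorophenyl on a saturated chain carbon bound to a nitrogen on an aromatic ring. Going by the values given here, no measured step involves a hydroxy-bearing ring, so the size of this change is uncertain; the two measured exchanges of the 4-fluorophenyl both moved toward weaker inhibition. Compound 4 is therefore expected to be weaker than compound 1 in this assay, with a step of a 3.3-fold higher number from compound 1 to compound 4 (0.52 log units; beyond the scatter) estimated. The estimated value for compound 4 is 70000 nM, within 20000 nM to 200000 nM, with a fair chance that only a limit is returned.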

Compound 4, half-maximal inhibitory concentration: 6900 nM
Compound 4: middle estimate off by 10-fold (1.01 log units), on the high side, outside the stated range (below it).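

In this assay, the place on a saturated chain carbon bound to a nitrogen on an aromatic ring can also gain inhibition: with 2-hydroxy-3-methylphenyl in place of 4-fluorophenyl, the result is a 3.0-fold lower number from compound 1 to compound 4 (0.48 log units; beyond the scatter), so exchanging the 4-fluorophenyl does not only weaken inhibition. Against the two other aryl groups the gap is wider, with an at least 24-fold lower number from compound 3 to compound 4 (1.38 log units; beyond the scatter) and an at least 24-fold lower number from compound 2 to compound 4 (1.38 log units; beyond the scatter). Compound 2 and compound 3 are known only through a limit, so these two steps give minimum sizes: the limit of > 166000 nM in this assay, at which 2 of the 4 values shown sit.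

On these data alone, whether the gain follows the hydroxy or the methyl stays open, as both enter together in compound 4. For the compounds shown here, also open is how a phenyl carrying only one of these two groups, or a methoxy in place of the hydroxy, would compare.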